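Chloro for Hydrogen on the Phenyl of Compound 1

The compounds below may be only part of what the source reports. "The series", "measured", "known", "first", "only" and "open" are said of these compounds alone.

Of the compounds shown here, two sharing the same core have been measured in a functional assay on NCI-H460 cells (Homo sapiens) for inhibition, read by sulforhodamine B assay, with a stated time of 48 h, tested at 10 uM; a higher number here means more inhibition of growth at the concentration tested, a lower number less inhibition of growth. Compound 1, with the structure `c1ccc(-c2nc3sc(-c4ccccc4)cn3n2)cc1`, carries an unsubstituted phenyl on each side of its core; in this assay compound 1 gives 6%. Compound 2, with the structure `COc1ccc(-c2nc3sc(-c4ccc(Cl)cc4)cn3n2)cc1`, differs from compound 1 in two places at once, and in this assay compound 2 gives -39%. Of these two numbers, compound 1 has the higher one, and the gap down to compound 2 lies beyond the scatter; still, neither compound shows much growth inhibition at the concentration tested.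

Compound 3, with the structure `Clc1ccc(-c2cn3nc(-c4ccccc4)nc3s2)cc1`, is not yet measured. It differs from compound 1 only in one spot: chloro in place of hydrogen on an aromatic carbon. Among the measured compounds shown here, no single-change step between measured compounds is available to lean on. Because compound 2 gives -39% while also carrying a chloro, a small move downward is plausible, but the step of a number 14 percentage points lower from compound 1 to compound 3 (beyond the scatter) is expected to stay within the scatter. Compound 3 is estimated at -8%, with a range from -40% to 20%.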

Compound 3, percent growth inhibition at one concentration: 37%
For compound 3 the middle estimate is 45 percentage points below the measured one, outside the stated range (above it).
By their numbers in this assay, from the lowest: compound 2; then compound 1; then compound 3.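

In this assay, going from phenyl to 4-chlorophenyl on the shared core is a large upward move, a number 31 percentage points higher from compound 1 to compound 3 (beyond the scatter) and so a single chloro at this place, para to a large group, goes with more growth inhibition, not less. The second step, a number 76 percentage points higher from compound 2 to compound 3 (beyond the scatter) is also large, and here the chloro stays in place while a methoxy gives way to hydrogen, so the low number of compound 2 cannot be read as a sign that the chloro lowers growth inhibition; within this pair, it is the presence of the methoxy that goes with the lower number. Nothing available here explains why either change has so large an effect.

The compounds shown leave open whether the rise belongs to chloro in particular or would also appear with another group at this place, such as fluoro, an amine or a carboxylic acid. Among the compounds shown here, they also leave open whether methoxy would lower the number in the same way on a compound without the chloro, since its effect is seen only with the chloro present.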